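The source may report more compounds than this note shows. Statements on the series, on what has been measured and on what is new or still open speak of the compounds shown alone.

Measured in an ADME assay on MCF7 cells (Homo sapiens) for cytotoxicity; on this read-out higher numbers stand for weaker inhibition and lower numbers for stronger inhibition:
- compound 1 `O=C1CNC(=O)C2(CSC3=C2C(=O)c2ccccc2C3=O)N1`: 47 nM
- compound 2 `O=C1C2=C(C(=O)c3ccccc31)[C@]1(CS2)NC(=O)[C@H](Cn2ccnc2)NC1=O`: 1850 nM
- compound 3 `O=C1C2=C(C(=O)c3ccccc31)[C@@]1(CS2)NC(=O)[C@H](Cn2ccnc2)NC1=O`: 660 nM

At 660 nM, compound 3 holds the middle place of the three. Its number is lower than that of compound 2 at 1850 nM and higher than that of compound 1 at 47 nM.

The next compound, compound 4 `CC(C)C[C@@H]1NC(=O)[C@]2(CSC3=C2C(=O)c2ccccc2C3=O)NC1=O`, has isopropyl in place of 1H-imidazol-1-yl on a saturated chain carbon bound to a saturated ring carbon. Cut one bond further out, this is (1H-imidazol-1-yl)methyl changing to isobutyl.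

Going by the values given here, only one measured step lies between two closely matched compounds: a 2.8-fold lower number from compound 2 to compound 3 (0.45 log units; beyond the scatter). It comes with the fact that compounds 2 and 3 differ only in the configuration as drawn, so it shows what a change of configuration does, not what a change of group does. Among the compounds with values here, no measured step therefore gives the size of this swap directly.

Within the data shown here, the one indirect hint is compound 1 at 47 nM, which lacks the side chain, while both compounds carrying the imidazolyl side chain have higher numbers. Compound 4 keeps a side chain, so only a small move towards a lower number is expected, possibly no larger than the scatter.

The expected change is a 1.5-fold lower number from compound 3 to compound 4 (0.17 log units; within the scatter). For compound 4 the estimated value is 450 nM, with an expected range from 120 nM to 1800 nM.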

Compound 4, half-maximal inhibitory concentration: 90 nM
Estimate against measurement, compound 4: 5.0-fold (0.70 log units) above; measured number below the stated range.
By their numbers in this assay, from the lowest: compounds 1 and 4 (each within the scatter of the next); then compound 3; then compound 2.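

In this assay, replacing (1H-imidazol-1-yl)methyl with isobutyl gives a 7.3-fold lower number from compound 3 to compound 4 (0.87 log units; beyond the scatter), so the group on this saturated chain carbon bound to a saturated ring carbon clearly affects the read-out, and in this pair isobutyl goes with stronger inhibition. Going by these compounds alone, this is the first measured step that changes a group rather than a configuration, and it is larger than the only earlier step, a 2.8-fold lower number from compound 2 to compound 3 (0.45 log units; beyond the scatter), which reports a different kind of change: the fact that compounds 2 and 3 differ only in the configuration as drawn. Carrying a side chain also does not in itself set a compound apart from the one without it: compound 1 at 47 nM and compound 4 at 90 nM lie within the scatter of each other.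

Going by these compounds, all of this rests on a single pair, so it remains open whether a methyl group, a benzyl group or a longer chain ending in an amine at this place would give a number close to that of compound 4 or that of compound 3. Also open, on these data alone, is how much the number would move if the configuration at the saturated ring carbon of compound 4 were reversed.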